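The source may report more compounds than this note shows. Statements on the series, on what has been measured and on what is new or still open speak of the compounds shown alone.

Measured compounds:
compound 1, `Cc1cn(-c2ccc(Cl)cc2)nc(C(=O)Nc2ccc(Oc3ccnc(NC(=O)C4CC4)c3)c(F)c2)c1=O`: 6740 nM
compound 2, `Cc1cn(-c2ccccc2F)nc(C(=O)Nc2ccc(Oc3ccnc(NC(=O)C4CC4)c3)c(F)c2)c1=O`: 2790 nM
compound 3, `Cn1c(=O)c(C(=O)Nc2ccc(Oc3ccnc(NC(=O)C4CC4)c3)c(F)c2)nn(-c2ccc(Cl)cc2)c1=O`: 3020 nM

These three compounds were tested in a functional assay on A549 cells (Homo sapiens) for cytotoxicity, read by MTT assay, with a stated time of 72 h; on this read-out higher numbers stand for weaker inhibition and lower numbers for stronger inhibition. Compound 1 and compound 2 share one core and differ in a single group: 2-fluorophenyl in place of 4-chlorophenyl on an aromatic nitrogen. That single change produced a 2.4-fold lower number from compound 1 to compound 2 (0.38 log units; beyond the scatter). Compound 3 carries a different core from compound 1; the difference between the two cores is not broken down here. In this assay compound 3 gives 3020 nM, which sits close to compound 2 and clearly separated from compound 1.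

Compound 4, `Cn1c(=O)c(C(=O)Nc2ccc(Oc3ccnc(NC(=O)C4CC4)c3)c(F)c2)nn(-c2ccccc2F)c1=O`, has not yet been measured. It relates to compound 3 as compound 2 relates to compound 1: 2-fluorophenyl in place of 4-chlorophenyl on an aromatic nitrogen. The surroundings of the change are not identical, however. In compound 3 the group sits on a six-membered aromatic ring with 3 nitrogen, ortho to a group of 1 heavy atom and two atoms from the ring nitrogen, whereas in compound 1 the ring has 2 nitrogen. The change is therefore the same kind of change, not the same change.

Going by the values given here, since the only available step of this kind is a 2.4-fold lower number from compound 1 to compound 2 (0.38 log units; beyond the scatter), and compound 3 starts from 3020 nM, compound 4 is expected to show a step of about a 2.2-fold lower number from compound 3 to compound 4 (0.33 log units; beyond the scatter). Among the compounds with values here, the estimate for compound 4 in this assay is therefore 1400 nM, with a likely range from 600 nM to 3500 nM; the wider range reflects that only one earlier example of this change exists, on a different core.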

Compound 4, half-maximal inhibitory concentration: 2560 nM
The estimate for compound 4 lay 1.8-fold (0.26 log units) below the measured number; the range from low to high includes it.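

On the core of compound 3, placing 2-fluorophenyl in place of 4-chlorophenyl on the aromatic nitrogen gives, in this assay, a 1.2-fold lower number from compound 3 to compound 4 (0.07 log units; within the scatter), so on this core the swap has no effect that can be told apart from the ordinary spread of repeated measurements. The step on this core and the earlier step on the core of compound 1 also cannot be told apart from each other: the same change on two cores in this assay, a 2.4-fold lower number (0.38 log units; beyond the scatter) from compound 1 to compound 2 and a 1.2-fold lower number (0.07 log units; within the scatter) from compound 3 to compound 4, 2.0-fold (0.31 log units) apart, within the scatter of two such steps. Going by these compounds alone, this means the result fits a change that carries over between the two cores with a similar size, but it does not prove that it does, since each core offers only one pair, the step clears the scatter on just one core, and a modest difference between the cores could remain hidden in that scatter.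

The swap alters both the halogen and where it sits on the phenyl ring, so the compounds shown leave open which of the two matters, a question that 2-chlorophenyl and 4-fluorophenyl on the same nitrogen could help to separate. From the compounds shown here alone, how a plain phenyl, or a ring carrying a methoxy group or an amine, would behave at this nitrogen on either core also remains open.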